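The source may report more compounds than this note shows. Statements on the series, on what has been measured and on what is new or still open speak of the compounds shown alone.

Series notes. Among the measured compounds shown here, compound 1 `Cc1ccc(S(=O)(=O)Oc2ccc3c(c2C)[C@H](Cn2cc(-c4ccccc4)nn2)[C@@]24CC(=O)[C@@](C)(CC[C@@H]32)C4)cc1` and compound 2 `C=C1C[C@]23C[C@@]1(O)CC[C@@H]2c1cccc(C)c1[C@@H]3Cn1cc(-c2ccccn2)nn1` are the two measured members. In a functional assay on A549 cells (Homo sapiens) for cytotoxicity, read by MTT assay, with a stated time of 4 days (on this read-out lower numbers stand for stronger inhibition and higher numbers for weaker inhibition), compound 1 gives only a limit of the assay, > 20000 nM. In this assay compound 2 likewise gives only a limit, > 20000 nM. Compound 2 therefore stands at the limit of > 20000 nM in this assay, at which 2 of the 2 values shown sit, and no number below that limit is shown for either compound, so no measured step can be sized and no direction can be read from the pair.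

Compound 3 `C=C1C[C@]23C[C@@]1(O)CC[C@@H]2c1cccc(C)c1[C@@H]3Cn1cc(-c2ccc(C)cc2)nn1` is not yet measured. It differs from compound 2 by 4-methylphenyl in place of pyridin-2-yl on an aromatic carbon. For the measured compounds named here, with no measured step to lean on, the expected step from compound 2 to compound 3 is a step that the limit leaves unreadable from compound 2 to compound 3, that is, no change beyond the scatter, because compound 2 rests at the limit of > 20000 nM in this assay, at which 2 of the 2 values shown sit. Compound 3 is accordingly estimated at 25000 nM, within a range from 8000 nM to 60000 nM, and most probably reported again as a limit rather than a number.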

Compound 3, half-maximal inhibitory concentration: > 20000 nM
Compound 3: no number, only a limit (the forecaster's own chance of this, stated with the estimate: 75%); the middle value lies beyond the limit too.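

In this assay, among the compounds shown here, compound 3 gives only a limit, as compound 2 does, so no step between compound 2 and compound 3 can be read: (the limit of > 20000 nM in this assay, at which 3 of the 3 values shown sit). The compounds shown leave open which groups, if any, would give a number rather than a limit in this assay on the shared core.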